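Urea series: chloro replacing acetyl, whole-organism read-out

The source may hold more compounds than are shown below. What is called first, only, known or untested is meant among the compounds shown, and "the series" means these compounds.

Measured so far:
Compound 1, `C[C@H](NC(=O)Nc1ccccc1C(F)(F)F)c1ccccc1`, gives 98% in an ADME assay on the whole organism with Oryza sativa as the target, tested at 1 uM; on this read-out higher numbers stand for a weaker effect at the one concentration tested and lower numbers for a stronger effect.
Compound 2, `CC(=O)c1ccccc1NC(=O)N[C@@H](C)c1ccccc1`, gives 97% in this assay.

Compound 2 holds the lowest of the two numbers in this assay, its nearest neighbour being compound 1, and the step of a number 1 percentage points lower from compound 1 to compound 2 (within the scatter) is within the scatter, so the two compounds cannot be told apart on this read-out. Compound 3, `C[C@H](NC(=O)Nc1ccccc1Cl)c1ccccc1`, has not yet been measured. It differs from compound 2 in one place: chloro in place of acetyl on an aromatic carbon. For the measured compounds named here, the only step known is the one from compound 1 to compound 2, which exchanged one group ortho to a large group for another without moving the number beyond the scatter. That step bears on the present change only loosely, since chloro is a new group here. Compound 3 is therefore expected to stay close to compound 2, with a step of a number 1 percentage points lower from compound 2 to compound 3 (within the scatter) in this assay, none beyond the scatter. The estimate for compound 3 is 96%, within 86% to 100%.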

Compound 3, a percentage reported as activity, at one concentration (the size of the read-out at that concentration, not a potency): 104%
Compound 3: the middle estimate sits 8 percentage points below what was measured; the whole stated range lies below it.
By their numbers in this assay, from the lowest: compounds 2, 1 and 3 (each within the scatter of the next).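

In this assay, chloro on this aromatic carbon, ortho to a large group, gives a step of a number 7 percentage points higher from compound 2 to compound 3 (within the scatter) against acetyl and a step of a number 6 percentage points higher from compound 1 to compound 3 (within the scatter) against trifluoromethyl. Chloro thus adds a third group at this place that cannot be told apart from the other two on this read-out, even though it has a single heavy atom and no hydrogen-bond acceptor, whereas acetyl has three heavy atoms and one such acceptor. No independent measurement is available to explain why these exchanges leave the read-out within the scatter.

From the compounds shown here alone, it remains open whether an amine or a carboxylic acid at this place would give a step beyond the scatter. The compounds shown also leave open whether a methoxy group elsewhere on this ring would separate from them.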